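Replacing Carbamoyl with Hydroxy in a Nicotinic Binding Series

The source may hold more compounds than are shown below. What is called first, only, known or untested is meant among the compounds shown, and "the series" means these compounds.

Two measured compounds share one core. In an assay on HEK293 cells for displacement of a labelled ligand from Neuronal acetylcholine receptor; alpha4/beta2 (Homo sapiens) (on this read-out higher numbers stand for weaker inhibition and lower numbers for stronger inhibition), compound 1 `C/C=C\Oc1cncc(N2CCCNCC2)c1` gives 1.29 nM. Compound 2 `NC(=O)c1cncc(N2CCCNCC2)c1` gives 20 nM in this assay, the highest of the two numbers, and the gap is the step of a 16-fold higher number from compound 1 to compound 2 (1.19 log units; beyond the scatter). Compound 3 `Oc1cncc(N2CCCNCC2)c1` differs from compound 2 by hydroxy in place of carbamoyl on an aromatic carbon. Within the data shown here, the only measured step, a 16-fold higher number from compound 1 to compound 2 (1.19 log units; beyond the scatter), concerns a different exchange at the same carbon and is large, but it offers no direct guide to a hydroxy group. Compound 3 is therefore expected close to compound 2, with an estimated step of a 1.5-fold higher number from compound 2 to compound 3 (0.18 log units; within the scatter) in this assay. The estimate for compound 3 is 30 nM, expected within 8 nM to 150 nM.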

Compound 3, half-maximal inhibitory concentration: 2.4 nM
The estimate for compound 3 lay 13-fold (1.10 log units) above the measured number, and the stated range ends above it.
By their numbers in this assay, from the lowest: compounds 1 and 3 (each within the scatter of the next); then compound 2.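

In this assay, hydroxy does not behave like carbamoyl on this aromatic carbon: the exchange gives an 8.3-fold lower number from compound 2 to compound 3 (0.92 log units; beyond the scatter) and brings the number back to the level of compound 1. Removing prop-1-en-1-yl from the oxygen gives a 1.9-fold higher number from compound 1 to compound 3 (0.27 log units; within the scatter), so this position tolerates either a free hydroxy or its prop-1-en-1-yl ether, while carbamoyl alone stands apart. Nothing available here accounts for that difference. On these data alone, whether an amine or a carboxylic acid on this carbon would side with hydroxy or with carbamoyl remains open, as does the effect of a longer chain on the oxygen.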